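The compounds below may be only part of what the source reports. "The series", "measured", "known", "first", "only" and "open" are said of these compounds alone.

Compounds measured so far in a functional assay for inhibition, with Homo sapiens as the target; a lower number here means tighter binding, a higher number weaker binding:
- compound 1 `N#Cc1ccc(C2OCC(C/C=C\CCC(=O)O)C(c3cccnc3)O2)cc1`, which gives 1290 nM
- compound 2 `O=C(O)CC/C=C\CC1COC(c2ccc(Cl)cc2Cl)OC1c1cccnc1`, which gives 891 nM
- compound 3 `CC(C)(C)c1ccc(OC(C)(C)C2OCC(C/C=C\CCC(=O)O)C(c3cccnc3)O2)cc1`, which gives 1910 nM

Compound 3 stands with the highest of the three numbers. Its nearest neighbour is compound 1, and the gap between them lies within the scatter, so no order between the two can be claimed; compound 2 is the furthest away, and that gap lies beyond the scatter.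

The step under consideration leads from compound 3 to compound 4 `CC(C)(Sc1ccccc1)C1OCC(C/C=C\CCC(=O)O)C(c2cccnc2)O1`. The change is phenylsulfanyl in place of 4-(tert-butyl)phenoxy on a saturated chain carbon bound to two saturated chain carbons and a saturated ring carbon.

Within the data shown here, only one measured step exists, a 1.4-fold lower number from compound 1 to compound 2 (0.16 log units; within the scatter), and it concerns a different place: an aromatic group on a saturated ring carbon, not the group on the saturated chain carbon that changes here. It therefore bears on the present step only loosely, showing that exchanging one aromatic substituent for another on this core has moved the number by little. Among the measured compounds shown here, with no closer precedent, the step to compound 4 is expected to stay near the scatter, a 1.3-fold lower number from compound 3 to compound 4 (0.10 log units; within the scatter), with a slight lean toward a lower number. Compound 4 is thus estimated at 1500 nM, within a range from 600 nM to 4000 nM.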

Compound 4, dissociation constant: 200 nM
For compound 4 the middle estimate is 7.5-fold (0.88 log units) above the measured one, and the stated range ends above it.
By their numbers in this assay, from the lowest: compound 4; then compounds 2, 1 and 3 (each within the scatter of the next, the first and the last beyond it).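

In this assay, among these compounds, phenylsulfanyl in place of 4-(tert-butyl)phenoxy on the saturated chain carbon gives a 9.6-fold lower number from compound 3 to compound 4 (0.98 log units; beyond the scatter), so this place can move the number well beyond the scatter, which the one earlier step, at a different place, did not do. The other comparisons point the same way, with a 4.5-fold lower number from compound 2 to compound 4 (0.65 log units; beyond the scatter) and a 6.5-fold lower number from compound 1 to compound 4 (0.81 log units; beyond the scatter), and these set compound 4 apart with the lowest number of the four.

The step changes two things at once, the atom joining the aromatic ring to the chain and the presence of tert-butyl, so phenoxy or 4-(tert-butyl)phenylsulfanyl on the same carbon would be needed to tell these apart. No evidence at hand says why the number falls at this position.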